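Swapping a terminal methyl for hydroxy on the sulfonamide chain

A few compounds are considered here, and "the series" means these few. Any claim that something is new, unique, unknown or untested is made for them only; others in the source may bear on it.

Of the compounds shown here, three sharing one core have been tested in an assay for inhibition of serine/threonine-protein kinase PLK2 (Homo sapiens), read by FRET and Z'-LYTE, with a stated time of 1 h; on this read-out lower numbers stand for stronger inhibition and higher numbers for weaker inhibition. Compound 1 `CCC1C(=O)N(C)c2cnc(Nc3ccc(S(=O)(=O)NCC(C)C)cc3)nc2N1c1ccn(C)n1` gives 311 nM in this assay. Compound 2 `CCCNS(=O)(=O)c1ccc(Nc2ncc3c(n2)N(c2ccn(C)n2)C(CC)C(=O)N3C)cc1` differs from it only in the chain on the sulfonamide nitrogen, and in this assay compound 2 gives 190 nM; the step of a 1.6-fold lower number from compound 1 to compound 2 (0.21 log units; within the scatter) shows that trimming that chain left the number essentially where it was. Compound 3 `CCCCNS(=O)(=O)c1ccc(Nc2ncc3c(n2)N(C2CCCC2)[C@H](CC)C(=O)N3C)cc1` carries a cyclopentyl group on the core in place of the methylpyrazole of the other two, and in this assay compound 3 gives 19.9 nM, the lowest of the three numbers and clearly separated from both compound 2 and compound 1.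

Compound 4 `CC[C@@H]1C(=O)N(C)c2cnc(Nc3ccc(S(=O)(=O)NCCCO)cc3)nc2N1C1CCCC1` keeps everything in compound 3 except one change at the far end of the sulfonamide chain: hydroxy in place of methyl on a saturated chain carbon, three bonds along the chain from a sulfonamide nitrogen. Within the data shown here, no measured pair shows exactly this swap. Among the measured compounds shown here, the only step that touches the same chain, a 1.6-fold lower number from compound 1 to compound 2 (0.21 log units; within the scatter), was within the scatter, which suggests that the sulfonamide chain tolerates small edits without a large shift, though that step changed chain length rather than introducing a hydroxy group.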

Compound 4, half-maximal inhibitory concentration: 8.16 nM
Beside the measured number, compound 4's estimate is 3.9-fold (0.59 log units) above it; the whole stated range lies above it.
By their numbers in this assay, from the lowest: compound 4; then compound 3; then compounds 2 and 1 (each within the scatter of the next).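

In this assay, among these compounds, the step of a 2.4-fold lower number from compound 3 to compound 4 (0.39 log units; beyond the scatter) is the first measured case of a hydroxy group on a saturated chain carbon, three bonds along the chain from a sulfonamide nitrogen, and although modest, it lies beyond the scatter. Among the compounds shown here, the earlier step on this chain, a 1.6-fold lower number from compound 1 to compound 2 (0.21 log units; within the scatter), stayed within the scatter, so this pair is the first to show a change on the sulfonamide chain that clearly moves the number. Going from butyl to 3-hydroxypropyl exchanges only one heavy atom and adds one hydrogen-bond donor and one hydrogen-bond acceptor, yet the number falls, and no measurement at hand gives a reason for this drop.

On these data alone, whether the hydroxy group itself matters or any similar end group would do the same remains open, and an amine, a carboxylic acid or a methoxy group at this chain end would help to separate those possibilities. As far as these compounds go, it is also open whether a longer chain ending in hydroxy would behave alike, and whether the same swap would lower the number with the methylpyrazole of compound 2 on the core.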